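A Longer Chain on the Core of Compound 1

This account rests on a few compounds, and the source may have more. Where it says the series, first, only, none or still open, it means among the compounds named here.

Compound 1 `CCCCCCCCCCn1cc(-c2nc3ccccc3cc2CC)nn1`, a limit in a functional assay on COLO 205 cells (Homo sapiens) for cytotoxicity, read by MTT assay, with a stated time of 24 h; on this read-out lower numbers stand for stronger inhibition and higher numbers for weaker inhibition: > 100 ug/mL
Compound 2 `CCc1cc2ccccc2nc1-c1cn(-c2ccc(F)cc2)nn1`, also a limit in this assay: > 100 ug/mL

Compound 1 stands at the limit of > 100 ug/mL in this assay, at which 2 of the 2 values shown sit, so the numbers shown place it no more exactly than that, and the same holds for its only companion. Compound 3 `CCCCCCCCCCn1cc(-c2nc3ccccc3cc2CCCCC)nn1` has not yet been measured. It differs from compound 1 by propyl in place of hydrogen on a saturated chain carbon, two bonds along the chain from an aromatic carbon. Among the compounds with values here, no step between measured compounds is on hand, so the effect of such a change cannot be read from any neighbouring pair. The writer therefore expects no step beyond the usual scatter in this assay, in either direction, and expects compound 3 to sit at a limit more often than at a number. For compound 3 the expected step is a step that the limit leaves unreadable from compound 1 to compound 3. The estimate for compound 3 in this assay is 150 ug/mL, with a range from 50 ug/mL to 450 ug/mL. What the measurement finally shows is the next question.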

Compound 3, half-maximal inhibitory concentration: > 100 ug/mL
Compound 3: a limit, no number; the forecaster's own chance of this, stated with the estimate: 70%; the middle value does not contradict the limit.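

Compound 3 gives [ > 100 ug/mL ] in this assay, which is a limit and not a number. Within the data shown here, compound 1 also sits at a limit, so no step between compound 1 and compound 3 can be read. The compounds shown leave open whether propyl in this place changes cytotoxicity at all.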